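A few compounds are considered here, and "the series" means these few. Any claim that something is new, unique, unknown or untested is made for them only; others in the source may bear on it.

Measured so far in a functional assay on DU-145 cells (Homo sapiens) for cytotoxicity, read by MTT assay; a lower number here means a stronger inhibitor, a higher number a weaker inhibitor:

Compound 1 `CC(C)=CC[C@@H](OC(=O)c1ccoc1)C1=CC(=O)c2c(O)ccc(O)c2C1=O` gives > 100000 nM, which is a limit of the assay rather than a number.
Compound 2 `CC(=O)OCCC(=O)O[C@H](CC=C(C)C)C1=CC(=O)c2c(O)ccc(O)c2C1=O` gives 15700 nM.
Compound 3 `CC[C@@](C)(O)CC(=O)O[C@H](CC=C(C)C)C1=CC(=O)c2c(O)ccc(O)c2C1=O` gives 12700 nM.

All three share the same core and differ only in the group carried on the oxygen of the side chain. Compound 1 sits at a limit (the limit of > 100000 nM in this assay, at which 1 of the 3 values shown sits), so its value is a boundary only. Compound 2 and compound 3 sit within the scatter of each other a 1.2-fold lower number from compound 2 to compound 3 (0.09 log units; within the scatter), so no order can be read between them. Moving from compound 1 to the other two gave an at least 6.3-fold lower number from compound 1 to compound 2 (0.80 log units; beyond the scatter) and an at least 7.8-fold lower number from compound 1 to compound 3 (0.89 log units; beyond the scatter).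

Compound 4 `COC(C)CO[C@H](CC=C(C)C)C1=CC(=O)c2c(O)ccc(O)c2C1=O` has not yet been measured in this assay. It differs from compound 3 in this way: 2-methoxypropyl in place of (2-hydroxy-2-methylbutyl)carbonyl on an oxygen on a saturated carbon. Going by the values given here, none of the measured steps removes the carbonyl itself, so no step bears directly on this change. Among the compounds with values here, the one step that alters the side chain beyond the carbonyl, a 1.2-fold lower number from compound 2 to compound 3 (0.09 log units; within the scatter), stayed within the scatter. Compound 4 is therefore expected to show a step of a 1.2-fold higher number from compound 3 to compound 4 (0.07 log units; within the scatter), nothing beyond the scatter. The estimate for compound 4 is 15000 nM, with a range from 4000 nM to 60000 nM.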

Compound 4, half-maximal inhibitory concentration: 16600 nM
For compound 4 the middle estimate is 1.1-fold (0.04 log units) below the measured one, within the range that was stated.
By their numbers in this assay, from the lowest: compounds 3, 2 and 4 (each within the scatter of the next). At a limit, above all of these: compound 1.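

In this assay, compound 4 is the first shown with no carbonyl on the oxygen on a saturated carbon, yet this change gives a 1.3-fold higher number from compound 3 to compound 4 (0.12 log units; within the scatter), and a 1.1-fold higher number from compound 2 to compound 4 (0.02 log units; within the scatter). The chain can therefore lose that carbonyl without any readable change in this assay, while the step of an at least 6.0-fold lower number from compound 1 to compound 4 (0.77 log units; beyond the scatter) shows that compound 1 stays apart from a chain without a carbonyl as well as from those with one. Compound 1 carries a limit, not a number, so that step gives only a minimum size: the limit of > 100000 nM in this assay, at which 1 of the 4 values shown sits.

The compounds shown leave open whether an amine, a carboxylic acid or a longer chain in place of 2-methoxypropyl would move the number beyond the scatter. They also leave open what furan-3-yl does on this oxygen without the carbonyl.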